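Shorter Chain with Fluorine on the Phenyl Ring

This account rests on a few compounds, and the source may have more. Where it says the series, first, only, none or still open, it means among the compounds named here.

In an assay on HEK293 cells for inhibition of acid ceramidase (Homo sapiens), with a stated time of 10 min (a higher number here means a weaker inhibitor, a lower number a stronger inhibitor), compound 1 `O=C(NCCCCc1ccccc1)n1c(=O)oc2ccc(Br)cc21` gives 22 nM. Compound 2 `O=C(NCCCCCc1ccccc1)n1c(=O)oc2ccccc21` gives 54 nM, the higher of the two numbers, and its gap to compound 1 lies beyond the usual scatter. Compound 3 `O=C(NCCCCc1ccc(F)cc1)n1c(=O)oc2ccccc21` differs from compound 2 in a single place: 4-fluorophenyl in place of benzyl on a saturated chain carbon, four bonds along the chain from an amide-type nitrogen. Within the data shown here, no measured pair shows this same change, so its effect is uncertain; a modest step toward a lower number is expected, about a 1.5-fold lower number from compound 2 to compound 3 (0.19 log units; within the scatter). Compound 3 is therefore estimated at 35 nM, with a likely range from 12 nM to 100 nM.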

Compound 3, half-maximal inhibitory concentration: 75 nM
The estimate for compound 3 lay 2.1-fold (0.33 log units) below the measured number; measured number inside the range.
By their numbers in this assay, from the lowest: compound 1; then compounds 2 and 3 (each within the scatter of the next).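

In this assay, placing 4-fluorophenyl where benzyl stood on this saturated chain carbon gives a 1.4-fold higher number from compound 2 to compound 3 (0.14 log units; within the scatter), so compound 2 and compound 3 cannot be told apart. Both groups hold 7 heavy atoms, with one carbon giving way to one fluorine, and at this position that exchange produces no readable difference. Nothing measured here offers an explanation for this result.

The compounds shown do not separate the effect of the shorter chain from that of the fluorine. On these data alone, how a chlorine or a methoxy group would read in the fluorine's place also remains open.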